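Dichlorophenyl for nitrophenyl on a quinazoline-type thioacetanilide

The source may hold more compounds than are shown below. What is called first, only, known or untested is meant among the compounds shown, and "the series" means these compounds.

The series shares one core, seen in compound 1 `CCc1cccc(NC(=O)CSc2nc(Nc3ccccc3)c3ccccc3n2)c1` and compound 2 `O=C(CSc1nc(Nc2ccccc2)c2ccccc2n1)Nc1ccc(F)cc1`, which in a functional assay on MDA-MB-231 cells (Homo sapiens) for inhibition, read by MTT assay, with a stated time of 72 h (on this read-out higher numbers stand for weaker inhibition and lower numbers for stronger inhibition), give compound 1 12400 nM and compound 2 34100 nM. Going by the values given here, the step of a 2.8-fold higher number from compound 1 to compound 2 (0.44 log units; beyond the scatter) is the only measured step. Compound 3 `C=CC(=O)Nc1cccc(NC(=O)CSc2nc(Nc3cccc([N+](=O)[O-])c3)c3ccccc3n2)c1` sits at a limit of this assay, > 50000 nM, so the limit of > 50000 nM in this assay, at which 1 of the 3 values shown sits, marks where compound 3 stands. Compound 4 `C=CC(=O)Nc1cccc(NC(=O)CSc2nc(Nc3ccc(Cl)cc3Cl)c3ccccc3n2)c1` differs from compound 3 by 2,4-dichlorophenyl in place of 3-nitrophenyl on a nitrogen on an aromatic ring. Among the compounds with values here, no measured step touches this position, and compound 3 offers no number to build on. Compound 4 is therefore expected at 45000 nM, within 15000 nM to 150000 nM, and its step from compound 3 is estimated as an at least 1.1-fold lower number from compound 3 to compound 4 (0.04 log units; that floor lies within the scatter), with a real chance that only a limit is again reported.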

Compound 4, half-maximal inhibitory concentration: 23100 nM
The estimate for compound 4 lay 1.9-fold (0.29 log units) above the measured number, and the stated range covers the measured number.
By their numbers in this assay, from the lowest: compounds 1, 4 and 2 (each within the scatter of the next, the first and the last beyond it). At a limit, above all of these: compound 3.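

Going by these compounds alone, on a nitrogen on an aromatic ring, 2,4-dichlorophenyl in place of 3-nitrophenyl gives an at least 2.1-fold lower number from compound 3 to compound 4 (0.33 log units; beyond the scatter), so this position, which no earlier step touched, does move the read-out in this assay. This step gives only a floor, not a size, for compound 3 stands at a limit: the limit of > 50000 nM in this assay, at which 1 of the 4 values shown sits.

The compounds shown leave open whether both chlorines are needed, or whether a single chlorine, a methoxy group or an amine on this ring would give a similar number.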